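Two chlorines in place of methylsulfanyl on the cinnamoyl ring

The source may report more compounds than this note shows. Statements on the series, on what has been measured and on what is new or still open speak of the compounds shown alone.

Going by the values given here, compound 2 `CCCc1cc(N)c2cc(NC(=O)/C=C/c3ccc(SC)cc3)ccc2n1` holds the lower of the two numbers measured so far in a functional assay on HEK293 cells for activation of melanin-concentrating hormone receptor 1 (Homo sapiens), read by inositol phosphate accumulation (on this read-out higher numbers stand for an effect only at larger amounts of compound and lower numbers for an effect already at smaller amounts), giving 71 nM. Among the compounds with values here, its only measured neighbour is compound 1 `CCCc1cc(N)c2cc(NC(=O)/C=C/c3ccc(F)cc3)ccc2n1`, which in this assay gives 200 nM; the single recorded step, a 2.8-fold lower number from compound 1 to compound 2 (0.45 log units; beyond the scatter), separates them and is the whole of what is known about this series.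

Compound 3 `CCCc1cc(N)c2cc(NC(=O)/C=C/c3ccc(Cl)cc3Cl)ccc2n1` has not yet been measured. It differs from compound 2 by 2,4-dichlorophenyl in place of 4-(methylsulfanyl)phenyl on a double-bonded chain carbon bound to a double-bonded chain carbon. Within the data shown here, the one measured step, a 2.8-fold lower number from compound 1 to compound 2 (0.45 log units; beyond the scatter), concerns the exchange of fluoro for methylsulfanyl at this same ring and bears on the new change only loosely, as neither compound 1 nor compound 2 carries two chlorines. With so little to go on, a shift of about a 1.4-fold higher number from compound 2 to compound 3 (0.15 log units; within the scatter) is expected for compound 3, which would not reach beyond the scatter. Compound 3 is therefore estimated at 100 nM in this assay, with a likely range from 30 nM to 400 nM.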

Compound 3, half-maximal effective concentration: 904 nM
The estimate for compound 3 lay 9.0-fold (0.96 log units) below the measured number; measured number above the stated range.
By their numbers in this assay, from the lowest: compound 2; then compound 1; then compound 3.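

In this assay, the exchange of 4-(methylsulfanyl)phenyl for 2,4-dichlorophenyl gives a 13-fold higher number from compound 2 to compound 3 (1.10 log units; beyond the scatter), a large step that shows this place tolerates substitution far less evenly than the modest 2.8-fold lower number from compound 1 to compound 2 (0.45 log units; beyond the scatter) had suggested. The same group is also unfavourable against 4-fluorophenyl, with a 4.5-fold higher number from compound 1 to compound 3 (0.66 log units; beyond the scatter), which makes compound 3 the least potent of the three, as its steps to both others lie beyond the scatter. Nothing measured here accounts for this rise in the number.

On these data alone, compound 3 brings in two chlorines in a single step, so it remains open whether one chlorine alone, as in 4-chlorophenyl or 2-chlorophenyl, would already give a higher number than compound 2 or whether the pair is needed. As far as these compounds go, it is equally open whether the lower number of compound 2 depends on the sulfur, a question that 4-methoxyphenyl or 4-(ethylsulfanyl)phenyl on the same chain carbon would address, and how any of these ring changes would behave with a different group elsewhere on the shared core.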